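Amine versus guanidine on the propoxy chain

The compounds below may be only part of what the source reports. "The series", "measured", "known", "first", "only" and "open" are said of these compounds alone.

Measured so far:
compound 1 `CN(Cc1ccc(OCCCN)cc1)c1nc2ccc(Oc3ccc(C#N)cc3)cc2s1` — 65000 nM
compound 2 `CN(Cc1ccc(OCCCNC(=N)N)cc1)c1nc2ccc(Oc3cccc(C(F)(F)F)c3)cc2s1` — 202000 nM

Compound 2 holds the highest of the two numbers in an assay on SH-SY5Y cells for inhibition of Voltage-dependent N-type calcium channel subunit alpha-1B (Homo sapiens), read by FLIPR and calcium flux, with stated times of 600 s and 300 s, in the presence of a further agent that is not named here; on this read-out lower numbers stand for stronger inhibition and higher numbers for weaker inhibition; compound 1 sits a good way lower, and the two compounds differ at two places, so the amine-versus-guanidine part of that gap cannot be separated. Compound 3 `CN(Cc1ccc(OCCCN)cc1)c1nc2ccc(Oc3cccc(C(F)(F)F)c3)cc2s1` keeps the trifluoromethyl aryl ether of compound 2 and carries the change (a hydrogen atom in place of a group of 3 heavy atoms (1 carbon, 2 nitrogen; no ring), on an amine nitrogen). For the measured compounds named here, no single-change step is available; a modest move toward lower numbers is expected, near the scatter. Compound 3 is estimated at 110000 nM, range 35000 nM to 350000 nM, a step of a 1.8-fold lower number from compound 2 to compound 3 (0.26 log units; within the scatter).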

Compound 3, half-maximal inhibitory concentration: 77000 nM
Estimate against measurement, compound 3: 1.4-fold (0.15 log units) above; the measured number falls inside the stated range.
By their numbers in this assay, from the lowest: compounds 1 and 3 (each within the scatter of the next); then compound 2.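

With the aryl ether held fixed, the guanidine-to-amine change on the propoxy chain can now be read alone: in this assay it gives a 2.6-fold lower number from compound 2 to compound 3 (0.42 log units; beyond the scatter). Compound 1 and compound 2 alone could not separate this change. With the amine in place, 3-(trifluoromethyl)phenyl in place of 4-cyanophenyl gives a 1.2-fold higher number from compound 1 to compound 3 (0.07 log units; within the scatter) and does not set the two aryl ethers apart. Still open, as far as these compounds go, is whether the guanidine step holds with 4-cyanophenyl on the oxygen, and where a carboxylic acid or a longer chain would fall. No measurement at hand gives a cause for either step.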